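The source may hold more compounds than are shown below. What is called first, only, known or untested is meant among the compounds shown, and "the series" means these compounds.

Measured so far in a physicochemical assay for acid dissociation:
- compound 1 `C/C=C/COc1noc2c1CNCC2`: 7.7
- compound 2 `c1ccc(COc2noc3c2CNCC3)cc1`: 7.5
- compound 3 `COc1noc2c1CN(Cc1ccccc1)CC2`: 6

Among these three, compound 1 stands at the upper end of the numbers, together with compound 2, since the two values lie within the usual scatter of each other. Compound 3 lies lower than compound 1, and that gap is well beyond the scatter.

The next compound, compound 4 `C=C(Br)COc1noc2c1CNCC2`, has not yet been measured in this assay. Its structure departs from compound 1 in one place (1-bromoethenyl in place of prop-1-en-1-yl on a saturated chain carbon bound to an oxygen on an aromatic ring), with 1-bromoethenyl in place of prop-1-en-1-yl on a saturated chain carbon bound to an oxygen on an aromatic ring.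

For the measured compounds named here, no measured pair isolates this change, so the expectation rests on thin evidence: compound 1 at 7.7 and compound 2 at 7.5 sit within the scatter of each other. A small downward move is expected, close to the size of the scatter, and the estimated step is a number 0.30 log units lower from compound 1 to compound 4 (within the scatter). For compound 4 the estimated value is 7.4, with an expected range from 7 to 7.8.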

Compound 4, acid dissociation constant: 7.6
The estimate for compound 4 lay 0.20 log units below the measured number, and the stated range covers the measured number.
By their numbers in this assay, from the lowest: compound 3; then compounds 2, 4 and 1 (each within the scatter of the next).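

In this assay, 1-bromoethenyl in place of prop-1-en-1-yl on a saturated chain carbon bound to an oxygen on an aromatic ring gives a number 0.10 log units lower from compound 1 to compound 4 (within the scatter), the first step shown that isolates one change at this position. Both groups have 3 heavy atoms and a double bond, yet one carries a bromine, so this exchange of carbon for bromine within the group leaves the two compounds indistinguishable in this read-out. Nothing measured here bears on the reason for this result.

As far as these compounds go, it remains open whether a fully saturated propyl chain or a longer chain at this position would also stay within the scatter of compound 1. An amine or a carboxylic acid placed on that chain might instead produce a step beyond the scatter.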